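Benzamide sulfonamide series: chlorine-to-fluorine swap on the amide aryl

A few compounds are considered here, and "the series" means these few. Any claim that something is new, unique, unknown or untested is made for them only; others in the source may bear on it.

Measured so far:
compound 1 `O=C(NCc1ccc(CNS(=O)(=O)c2ccccc2)cc1)c1cccc(Cl)c1`, 1000 nM
compound 2 `Cc1ccc(S(=O)(=O)NCc2ccc(CNC(=O)c3cccc(C)c3)cc2)cc1`, 1000 nM

In an assay on MDA-MB-231 cells for binding affinity to C-X-C chemokine receptor type 4 (Homo sapiens), read by immunofluorescence and microscopy, with stated times of 10 min and 30 min (on this read-out higher numbers stand for an effect only at larger amounts of compound and lower numbers for an effect already at smaller amounts), compound 1 gives 1000 nM. Compound 2 in this assay gives 1000 nM, level with compound 1 at the digits shown; the two readings sit within the scatter of each other, so nothing separates them. Going by the values given here, no step between measured compounds that differ in one place is available, so the series gives no calibration for a single substituent exchange.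

Compound 3 `O=C(NCc1ccc(CNS(=O)(=O)c2ccccc2)cc1)c1ccc(F)cc1` keeps the shared core of compound 1 and differs from it by a single exchange: 4-fluorophenyl in place of 3-chlorophenyl on a carbonyl carbon. Among the compounds with values here, with no measured step of this kind to lean on, the expectation rests on the flat pair above: a step from compound 1 to compound 3 of a 1.2-fold higher number from compound 1 to compound 3 (0.08 log units; within the scatter) is estimated, that is, no change beyond the scatter, with a slight lean toward weaker binding. Compound 3 is therefore expected to read about 1200 nM in this assay, between 500 nM and 3000 nM.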

Compound 3, effective concentration (reported as EC, without a stated level of effect): 100 nM
Compound 3: middle estimate off by 12-fold (1.08 log units), on the high side; measured number outside the range, below it.
By their numbers in this assay, from the lowest: compound 3; then compounds 1 and 2 (each within the scatter of the next).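

In this assay, going by these compounds alone, the aryl group on the amide carbonyl turns out not to be silent: 4-fluorophenyl in place of 3-chlorophenyl on a carbonyl carbon gives a 10-fold lower number from compound 1 to compound 3 (1.00 log units; beyond the scatter), the first step beyond the scatter. The heavy-atom count of the group stays the same, so a step of this size can arise here from exchanging one halogen and its ring place alone. No measured evidence bears on what lies behind the step.

The step joins two changes, the halogen and its place on the ring, and the compounds shown cannot separate them; 3-fluorophenyl and 4-chlorophenyl on the same carbonyl would do so. Also open, from the compounds shown here alone, is whether this position tolerates a non-halogen group, such as an amine or a carboxylic acid on the ring.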